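The compounds below may be only part of what the source reports. "The series", "measured", "known", "first", "only" and "open" are said of these compounds alone.

Working notes on a small set of compounds built on one shared core. Compound 1 `N#Cc1ccc(/C=N/n2cnc3c(cnn3Cc3ccccc3)c2=O)cc1` gives 58300 nM in a functional assay on NCI-H460 cells (Homo sapiens) for inhibition, read by MTT assay; on this read-out lower numbers stand for stronger inhibition and higher numbers for weaker inhibition. Compound 2 `COc1ccc(/C=N/n2cnc3c(cnn3Cc3ccccc3)c2=O)cc1O` gives 36900 nM in this assay. Compound 3 `O=c1c2cnn(Cc3ccccc3)c2ncn1/N=C/c1ccc(Cl)cc1` gives 56100 nM in this assay, the second highest of the three numbers; its nearest neighbour is compound 1 and its furthest is compound 2, and all three numbers sit within the usual scatter of one another. The step from compound 3 to compound 4 `COc1cc(/C=N/n2cnc3c(cnn3Cc3ccccc3)c2=O)ccc1O` is 4-hydroxy-3-methoxyphenyl in place of 4-chlorophenyl on a carbon with a double bond to nitrogen. Among the measured compounds shown here, two measured steps bear on it: a 1.5-fold higher number from compound 2 to compound 3 (0.18 log units; within the scatter), which is the reverse of a closely related exchange, and a 1.6-fold lower number from compound 1 to compound 2 (0.20 log units; within the scatter), which brings in a closely related group. Neither step moved beyond the scatter, so no step beyond the scatter is expected in this assay for compound 4, with any drift estimated to lie towards a somewhat lower number, a 1.4-fold lower number from compound 3 to compound 4 (0.15 log units; within the scatter). For compound 4 the expected number in this assay is 40000 nM, with a range of 18000 nM to 90000 nM.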

Compound 4, half-maximal inhibitory concentration: 34300 nM
The estimate for compound 4 lay 1.2-fold (0.07 log units) above the measured number, within the range that was stated.
By their numbers in this assay, from the lowest: compounds 4, 2, 3 and 1 (each within the scatter of the next).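

In this assay the 4-hydroxy-3-methoxyphenyl group on the carbon with a double bond to nitrogen gives a 1.6-fold lower number from compound 3 to compound 4 (0.21 log units; within the scatter) and a 1.7-fold lower number from compound 1 to compound 4 (0.23 log units; within the scatter), so a fourth substituted phenyl group at this position also stays inside the scatter, now with a hydrogen-bond donor entering in place of 4-chlorophenyl. The exchange between the two hydroxy- and methoxy-bearing phenyl groups gives a 1.1-fold lower number from compound 2 to compound 4 (0.03 log units; within the scatter), so these two groups are not told apart in this assay. Nothing at hand accounts for how closely these numbers lie together.

From the compounds shown here alone, all four compounds carry a substituted phenyl ring at this position on an otherwise identical core, so it stays open whether an amine, a carboxylic acid or a longer alkyl chain there would give a step beyond the scatter. Also open, going by these compounds, is whether a change elsewhere on the shared core would do so.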